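The compounds below may be only part of what the source reports. "The series", "measured", "known", "first", "only" and "open" are said of these compounds alone.

Working notes on the series. In an in vitro functional assay on 1321-N1 cells for agonist activity at P2Y purinoceptor 4 (Homo sapiens), read by scintillation proximity assay and inositol phosphate accumulation (a higher number here means that more compound is needed for the effect, a lower number that less compound is needed), compound 3 `COc1nc(=O)ccn1[C@@H]1O[C@H](COP(=O)(O)OP(=O)(O)O)[C@@H](O)[C@H]1O` gives 4490 nM. Compound 1 `CCSc1nc(=O)ccn1[C@@H]1O[C@H](COP(=O)(O)O)[C@@H](O)[C@H]1O` gives 4330 nM in this assay, and the two numbers sit within the scatter of each other. Compound 2 `CNc1nc(=O)ccn1[C@@H]1O[C@H](COP(=O)(O)O)[C@@H](O)[C@H]1O` reaches only the limit > 100000 nM in this assay, a limit and not a number; the limit of > 100000 nM in this assay, at which 1 of the 3 values shown sits, marks it. Going by the values given here, the one measured step, an at least 23-fold higher number from compound 1 to compound 2 (1.36 log units; beyond the scatter), concerns the substituent on the aromatic carbon and not the phosphate chain.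

Compound 4 `COc1nc(=O)ccn1[C@@H]1O[C@H](COP(=O)(O)O)[C@@H](O)[C@H]1O` differs from compound 3 by a hydrogen atom in place of a group of 4 heavy atoms (3 oxygen, 1 phosphorus; no ring), on an oxygen. Among the compounds with values here, no measured step bears on a change of the phosphate chain, so the size of the step in this assay is open. For compound 4 a higher number is expected, 20000 nM with a range of 3000 nM to 100000 nM, with a fair chance of a limit; the step so estimated is a 4.5-fold higher number from compound 3 to compound 4 (0.65 log units; beyond the scatter).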

Compound 4, half-maximal effective concentration: > 100000 nM
Compound 4: no number, only a limit; the forecaster's own chance of this, stated with the estimate: 30%; at least 5.0-fold (0.69 log units) between middle value and limit.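

In this assay, the phosphate chain proves to matter as much as the substituent on the aromatic carbon: an at least 22-fold higher number from compound 3 to compound 4 (1.34 log units; beyond the scatter), with a hydrogen atom in place of the group of 4 heavy atoms on an oxygen. With the chain held the same, methoxy in place of ethylsulfanyl also gives a large change, an at least 23-fold higher number from compound 1 to compound 4 (1.36 log units; beyond the scatter), so methoxy joins methylamino in that comparison. Compound 2 and compound 4 both end at a limit, and the step between them cannot be read: the limit of > 100000 nM in this assay, at which 2 of the 4 values shown sit.

Open, from the compounds shown here alone, is whether ethylsulfanyl on the longer chain of compound 3 would shift the number. Also open, going by these compounds, is how a propylsulfanyl group on the aromatic carbon would read.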